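The source may hold more compounds than are shown below. What is called first, only, known or untested is meant among the compounds shown, and "the series" means these compounds.

Measured so far in a functional assay on B16-F10 cells (Mus musculus) for antiproliferative activity, read by ELISA and MTT assay, with a stated time of 48 h; on this read-out lower numbers stand for stronger inhibition and higher numbers for weaker inhibition:
Compound 1 `O=C(/C=C/c1ccc(F)cc1)NS(=O)(=O)c1ccc(F)cc1` gives 0.8 ug/mL.
Compound 2 `COc1ccc(/C=C/C(=O)NS(=O)(=O)c2ccc(F)cc2)cc1` gives 5.1 ug/mL.

Of these two numbers, compound 2 stands highest, which here means the weaker inhibition of the pair: a 6.4-fold higher number from compound 1 to compound 2 (0.80 log units; beyond the scatter), a step beyond the scatter. Compound 3 `O=C(/C=C/c1ccc([N+](=O)[O-])cc1)NS(=O)(=O)c1ccc(F)cc1` differs from compound 2 in a single place: nitro in place of methoxy on an aromatic carbon. Among the compounds with values here, no measured step exchanges methoxy for nitro, so nothing bears directly on this change. Within the data shown here, the only step known on the shared core, a 6.4-fold higher number from compound 1 to compound 2 (0.80 log units; beyond the scatter), shows that swapping the group at this place can shift the number beyond the scatter, yet it involves a different pair of groups. With no comparable pairing for nitro, the expected step in this assay is uncertain in direction and is estimated to be modest: a 2.6-fold lower number from compound 2 to compound 3 (0.41 log units; beyond the scatter). Compound 3 is accordingly expected to give 2 ug/mL, with a range from 0.5 ug/mL to 8 ug/mL.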

Compound 3, half-maximal inhibitory concentration: 2.2 ug/mL
Beside the measured number, compound 3's estimate is 1.1-fold (0.04 log units) below it; the range from low to high includes it.
By their numbers in this assay, from the lowest: compound 1; then compound 3; then compound 2.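

Nitro in place of methoxy gives a 2.3-fold lower number from compound 2 to compound 3 (0.37 log units; beyond the scatter) and nitro in place of fluoro gives a 2.8-fold higher number from compound 1 to compound 3 (0.44 log units; beyond the scatter) in this assay so nitro lands between the two earlier groups and is clearly separated from both. This place therefore gives three distinct levels rather than the single contrast seen before, and nitro, with more heavy atoms and more hydrogen-bond acceptors than methoxy, still gives the lower number of that pair, so those counts alone do not set the order. Nothing measured here explains this order.

The compounds shown leave open how an amine, a hydroxyl or a plain methyl at this place would compare with these three groups. They also leave open whether the same order would hold with chlorine in place of the fluoro on the other aromatic ring.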